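The compounds below may be only part of what the source reports. "The series", "measured", "known", "first", "only" and "open" are said of these compounds alone.

Measured compounds:

- compound 1, `COC(=O)C1=C(C)N(C)C(=O)NC1c1cccs1`, in an assay on membranes from CHO cells for displacement of a labelled ligand from adenosine receptor A1 (Homo sapiens), read by scintillation counting, with a stated time of 60 min, tested at 1 uM (a lower number here means less inhibition, a higher number more inhibition at the concentration tested (going by the name of the read-out)), compound 1 gives 30%
- compound 2, `CCOC(=O)C1=C(C)N(C)C(=O)NC1c1cccs1`, in this assay compound 2 gives 1%

Compound 2 stands lowest of the two numbers in this assay; its nearest neighbour is compound 1, higher by a step beyond the scatter. Among the compounds with values here, the one measured step is a number 29 percentage points lower from compound 1 to compound 2 (beyond the scatter), a lengthening of the chain by one carbon that cost a modest amount of inhibition. Compound 3, `CCCOC(=O)C1=C(C)N(C)C(=O)NC1c1cccs1`, carries the same kind of lengthening one bond further out: methyl in place of hydrogen on a saturated chain carbon, two bonds along the chain from an oxygen next to a carbonyl group. Within the data shown here, only that single step bears on the change, and it points downward, but compound 2 already sits close to no inhibition, so there is little room left to fall. The expected step in this assay is a number 2 percentage points higher from compound 2 to compound 3 (within the scatter), essentially none beyond the scatter. Compound 3 is therefore estimated at 3%, within the range -8% to 18%.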

Compound 3, a percentage reported as inhibition, at one concentration (the size of the read-out at that concentration, not a potency): 9%
Compound 3: the middle estimate sits 6 percentage points below what was measured; low and high end bracket the measured number.
By their numbers in this assay, from the lowest: compounds 2 and 3 (each within the scatter of the next); then compound 1.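

In this assay, the change from ethoxy to propoxy, methyl in place of hydrogen on a saturated chain carbon two bonds along the chain from an oxygen next to a carbonyl group, gives a number 8 percentage points higher from compound 2 to compound 3 (within the scatter), so this second lengthening does not continue the fall seen with the first. Ethyl in place of hydrogen on the chain carbon bound to that oxygen gives a number 21 percentage points lower from compound 1 to compound 3 (beyond the scatter), so among these three compounds the loss of inhibition appears with the first added carbon, and the second adds nothing that can be told apart. Nothing available explains why inhibition follows this course.

From the compounds shown here alone, whether a longer chain such as butoxy, or a branched one such as isopropoxy, stays just as low remains open. So does whether an amide or a carboxylic acid in place of the ester restores inhibition.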